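The compounds below may be only part of what the source reports. "The series", "measured", "known", "first", "only" and "open" are said of these compounds alone.

Working notes on the chain series. Compound 1 `CCOC(=O)CCC(=O)N1CCN(CCCOc2cc3c(Nc4ccc(F)c(Cl)c4)ncnc3cc2OC)CC1` gives, in a functional assay on A549 cells (Homo sapiens) for cytotoxicity, read by MTT assay, with a stated time of 24 h, tested at 80 uM (a higher number here means a weaker effect of the compound at the concentration tested, a lower number a stronger effect), 35.6%. Compound 2 `CCCCOC(=O)CCC(=O)N1CCN(CCCOc2cc3c(Nc4ccc(F)c(Cl)c4)ncnc3cc2OC)CC1` gives in this assay 36.9%, and compound 3 `CCCCCOC(=O)CCC(=O)N1CCN(CCCOc2cc3c(Nc4ccc(F)c(Cl)c4)ncnc3cc2OC)CC1` gives in this assay 18.2%. Compound 3 stands lowest of the three: its nearest neighbour is compound 1 and its furthest compound 2, and both gaps lie beyond the scatter.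

The steps between the measured compounds are all of one kind, a lengthening of the same saturated chain. a number 1.3 percentage points higher from compound 1 to compound 2 (within the scatter). a number 17.4 percentage points lower from compound 1 to compound 3 (beyond the scatter). a number 18.7 percentage points lower from compound 2 to compound 3 (beyond the scatter).

Compound 4 `CCCCCCCOC(=O)CCC(=O)N1CCN(CCCOc2cc3c(Nc4ccc(F)c(Cl)c4)ncnc3cc2OC)CC1` is the next member. It differs from compound 3 as follows: ethyl in place of hydrogen on a saturated chain carbon, five bonds along the chain from an oxygen next to a carbonyl group. Read one bond further out, the change is propyl to pentyl. For the measured compounds named here, the steps that bear on it are those from compound 1 to compound 3 and from compound 2 to compound 3, both of which lowered the number by a modest amount, while the step from compound 1 to compound 2 lay within the scatter. A further lowering in this assay is therefore expected, but with only three points the size is uncertain; the step is estimated as a number 7.2 percentage points lower from compound 3 to compound 4 (within the scatter). For compound 4 the expected value in this assay is 11%, in the range 3% to 26%.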

Compound 4, a percentage reported as activity, at one concentration (the size of the read-out at that concentration, not a potency): 27.2%
For compound 4 the middle estimate is 16.2 percentage points below the measured one; the whole stated range lies below it.
By their numbers in this assay, from the lowest: compounds 3, 4, 1 and 2 (each within the scatter of the next, the first and the last beyond it).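

In this assay, the further lengthening does not carry on the lowering seen at compound 3: the new steps read a number 9 percentage points higher from compound 3 to compound 4 (within the scatter), a number 9.7 percentage points lower from compound 2 to compound 4 (within the scatter) and a number 8.4 percentage points lower from compound 1 to compound 4 (within the scatter), so compound 4 cannot be separated from any of the three shorter members. For the compounds shown here, the earlier compounds alone allowed a reading of a drop that might continue along the chain, whereas compound 3 now remains the only member set apart, and only from compound 1 and compound 2, and no steady dependence on chain length can be claimed at this position. The two pairs that share a change give no sign that the change acts differently in its two settings, the first pair showing: the same change on two cores in this assay, a number 1.3 percentage points higher (within the scatter) from compound 1 to compound 2 and a number 9 percentage points higher (within the scatter) from compound 3 to compound 4, 7.7 percentage points apart, within the scatter of two such steps. The second pair, with a larger change, agrees in the same way: the same change on two cores in this assay, a number 17.4 percentage points lower (beyond the scatter) from compound 1 to compound 3 and a number 9.7 percentage points lower (within the scatter) from compound 2 to compound 4, 7.7 percentage points apart, within the scatter of two such steps.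

As far as these compounds go, whether the separate position of compound 3 marks a real optimum or a single point remains open, since compound 4 overlaps it and its neighbours alike. Also open, from the compounds shown here alone, is how a longer chain, or an amine or a carboxylic acid at the far end of this chain, would read in this assay.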